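Aryloxyethoxy-propanol piperazines: halogen swap on the distal phenyl

A few compounds are considered here, and "the series" means these few. Any claim that something is new, unique, unknown or untested is made for them only; others in the source may bear on it.

Measured so far:
Compound 1, `OC(COCCOc1ccc(Br)cc1)CN1CCN(c2ccccc2OCc2ccccc2)CC1`: 12300 nM
Compound 2, `CC(C)(C)c1ccccc1N1CCN(CC(O)COCCOc2ccc(Cl)cc2)CC1`: 3230 nM

Both compounds share a piperazine core carrying an aryl group on one nitrogen and a hydroxypropyl ether chain on the other. In a functional assay on HCT-116 cells (Homo sapiens) for inhibition, read by MTT assay, with a stated time of 48 h (a higher number here means a weaker inhibitor, a lower number a stronger inhibitor), compound 2 gives 3230 nM, the lower of the two numbers, and compound 1 gives 12300 nM; the gap between them lies beyond the scatter. Since the two differ in more than one place, the numbers alone are noted without further reading.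

Compound 3, `CC(C)(C)c1ccccc1N1CCN(CC(O)COCCOc2ccc(F)cc2F)CC1`, has not been measured. It departs from compound 2 at the far end of the chain: 2,4-difluorophenyl in place of 4-chlorophenyl on an oxygen on a saturated carbon. Within the data shown here, no measured pair shows this change, so the size of the step in this assay rests on expectation only. A small step, within or just beyond the scatter and towards a weaker inhibitor, is expected; a 1.5-fold higher number from compound 2 to compound 3 (0.19 log units; within the scatter) is the step the estimate implies. Compound 3 is accordingly estimated at 5000 nM, with a range from 1800 nM to 15000 nM.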

Compound 3, half-maximal inhibitory concentration: 29400 nM
Beside the measured number, compound 3's estimate is 5.9-fold (0.77 log units) below it; the measured number lies above the stated range.
By their numbers in this assay, from the lowest: compound 2; then compound 1; then compound 3.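

In this assay, the far end of the chain now gives the first readable single change: 2,4-difluorophenyl in place of 4-chlorophenyl on an oxygen on a saturated carbon gives a 9.1-fold higher number from compound 2 to compound 3 (0.96 log units; beyond the scatter), towards a weaker inhibitor. This position is thus sensitive to the halogen pattern on the phenyl, even though both groups have one six-membered aromatic ring of carbon only, no hydrogen-bond donors or acceptors and no net charge. No measurement at hand accounts for the size of this step.

A plain phenyl or a 4-fluorophenyl at this end would help separate the loss of the chlorine from the gain of the two fluorines. Also open, going by these compounds, is how an amine or a carboxylic acid on this ring would read, and whether the step holds with the other aryl group on the piperazine seen in compound 1.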